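Replacing the bromo group of compound 2 with hydrogen

The compounds below may be only part of what the source reports. "The series", "measured", "known", "first", "only" and "open" are said of these compounds alone.

In a functional assay on NCI-H1299 cells (Homo sapiens), read by flow cytometry (a lower number here means that less compound is needed, a higher number that more compound is needed for the effect), compound 1 `N#Cc1ncc2nc1OCC/C=C\COc1ccc(O)cc1NC(=O)N2` gives > 10000 nM, which is a limit of the assay and not a number. Compound 2 `N#Cc1ncc2nc1OCC/C=C\COc1ccc(Br)cc1NC(=O)N2` gives > 10000 nM, which is also a limit. Compound 2 therefore stands at the limit of > 10000 nM in this assay, at which 2 of the 2 values shown sit. The next structure is compound 3 `N#Cc1ncc2nc1OCC/C=C\COc1ccccc1NC(=O)N2`, and the change is hydrogen in place of bromo on an aromatic carbon. Within the data shown here, the only measured step that bears on this change is a step that the two limits leave unreadable from compound 1 to compound 2, and it offers no size to carry over. Compound 1 and compound 2 share the same limit, so compound 3 is expected to stay close to it, with no firm direction. The expected step is an at least 1.2-fold lower number from compound 2 to compound 3 (0.09 log units; that floor lies within the scatter). For compound 3 the estimated half-maximal effective concentration is 8000 nM, with an expected range of 2500 nM to 20000 nM.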

Compound 3, half-maximal effective concentration: > 10000 nM
Compound 3: only a limit was reported (the forecaster's own chance of this, stated with the estimate: 60%); middle value at least 1.2-fold (0.09 log units) from the limit.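

In this assay compound 3 gives > 10000 nM, again a limit of the assay and not a number, so its steps from compound 1 and compound 2 cannot be read. The compounds shown leave open how hydroxy, bromo and hydrogen on this aromatic carbon compare, as none of the three gives a number.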